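Swapping tert-butyl for methoxy on a long-lived compound

This account rests on a few compounds, and the source may have more. Where it says the series, first, only, none or still open, it means among the compounds named here.

Compound 1 `CCCCCCNc1ccc([N+](=O)[O-])cc1S(N)(=O)=O`: < 0.0834 h (a limit)
Compound 2 `CCCCCCCCNc1ccc([N+](=O)[O-])cc1S(N)(=O)=O`: < 0.0834 h (a limit)
Compound 3 `CN(C)S(=O)(=O)c1cc(C(=O)O)ccc1NCCC(C)(C)C`: > 1 h (a limit)

All three results come from an ADME assay on microsomes from liver (Mus musculus) for metabolic stability, tested at 5 uM (on this read-out higher numbers stand for a longer-lived compound and lower numbers for a shorter-lived compound), and each is a limit of the assay rather than a number. Compound 1 and compound 2 share one limit: the limit of < 0.0834 h in this assay, at which 2 of the 3 values shown sit. Compound 3 stands at the long-lived end of the values shown: the limit of > 1 h in this assay, at which 1 of the 3 values shown sits.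

Compound 4 `COCCNc1ccc(C(=O)O)cc1S(=O)(=O)N(C)C` has not yet been measured. It carries methoxy in place of the tert-butyl of compound 3, on a saturated chain carbon, two bonds along the chain from a nitrogen on an aromatic ring (methoxy in place of tert-butyl on a saturated chain carbon, two bonds along the chain from a nitrogen on an aromatic ring).

Within the data shown here, only one measured step exists to compare with: a step that the two limits leave unreadable from compound 1 to compound 2. It also changes a chain, but its size cannot be read, and the core of compound 1 is not the core of compound 3. It therefore sets no size for the new change. No step beyond the usual scatter is expected in this assay, and no direction can be favoured. The expected step is a step that the limit leaves unreadable from compound 3 to compound 4. Compound 4 may well be reported as a limit too. For compound 4 the estimated half-life is 1.5 h, with an expected range from 0.6 h to 4 h.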

Compound 4, half-life: > 1 h
Compound 4: a limit, no number; the forecaster's own chance of this, stated with the estimate: 70%; the middle value is on the limit's open side.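

In this assay, compound 3 and compound 4 are both reported as limits rather than numbers, and the step between them cannot be read. The compounds shown leave open how long either compound actually lasts, and whether methoxy in place of tert-butyl alters the half-life at all.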